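Hydroxy to methoxy on compound 2

The source may hold more compounds than are shown below. What is called first, only, known or untested is meant among the compounds shown, and "the series" means these compounds.

Measured in a functional assay, read by spectrophotometry, with a stated time of 30 min; on this read-out higher numbers stand for weaker inhibition and lower numbers for stronger inhibition:
- compound 1 `CCOC(=O)CNC(=O)/C=C/c1ccc(O)cc1`: > 200000 nM (a limit of the assay)
- compound 2 `CCOC(=O)CNC(=O)/C=C/c1ccc(O)c(O)c1`: 12800 nM

Among the measured compounds shown here, compound 2 holds the only true number so far, 12800 nM. Compound 3 `CCOC(=O)CNC(=O)/C=C/c1ccc(O)c(OC)c1` is still to be measured. It differs from compound 2 by methyl in place of hydrogen on an oxygen on an aromatic ring, that is, hydroxy to methoxy.

For the measured compounds named here, one measured step bears on this change: an at least 15-fold lower number from compound 1 to compound 2 (1.19 log units; beyond the scatter). This large step is a bound rather than an exact size, as it starts from the limit of > 200000 nM in this assay, at which 1 of the 2 values shown sits. The hydroxy added in that step is the group that compound 3 carries as methoxy. A clear step to a higher number in this assay is therefore expected, meaning weaker inhibition, and it may reach the limit of the assay.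

The estimated step is a 5.5-fold higher number from compound 2 to compound 3 (0.74 log units; beyond the scatter). For compound 3 the expected value is 70000 nM, with an estimated range of 22000 nM to 200000 nM.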

Compound 3, half-maximal inhibitory concentration: 64600 nM
For compound 3 the middle estimate is 1.1-fold (0.03 log units) above the measured one, and the stated range covers the measured number.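

In this assay, capping the added hydroxy as methoxy gives back a real part of the gain, with a 5.0-fold higher number from compound 2 to compound 3 (0.70 log units; beyond the scatter). Methoxy still compares well with hydrogen on the same aromatic carbon, with an at least 3.0-fold lower number from compound 1 to compound 3 (0.49 log units; beyond the scatter). The earlier step from hydrogen to hydroxy therefore splits in two: a group on this carbon already lowers the number, and the hydrogen on its oxygen lowers it further, though the first part is only a bound, as compound 1 stands at a limit: the limit of > 200000 nM in this assay, at which 1 of the 3 values shown sits.

The compounds shown leave open whether an amine at this place would match the hydroxy of compound 2, and whether a longer chain on this oxygen, such as ethoxy, would raise the number further than methoxy in compound 3. Also open, going by these compounds, is how the series would respond to a carboxylic acid in place of the ethyl ester.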